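From methoxy to hydroxy on an aromatic ring

The source may report more compounds than this note shows. Statements on the series, on what has been measured and on what is new or still open speak of the compounds shown alone.

Values in an in vivo ADME assay on the whole organism (plasma) for pharmacokinetics, with Rattus norvegicus as the target, at a dose of 50 mg/kg by the oral route (on this read-out higher numbers stand for higher exposure at the dose given and lower numbers for lower exposure), so far:
- compound 1 `CC(=O)OCc1c(C)cc(C)c(NC(=O)c2sccc2S(=O)(=O)Nc2onc(C)c2Cl)c1C` gives 7420 nM
- compound 2 `COc1c(C)cc(C)c(NC(=O)c2sccc2S(=O)(=O)Nc2onc(C)c2Cl)c1C` gives 8510 nM
- compound 3 `Cc1cc(C)c(NC(=O)c2sccc2S(=O)(=O)Nc2onc(C)c2Cl)c(C)c1C#N` gives 37200 nM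

Compound 2 (8510 nM) lies within the scatter of compound 1 and sits lower than compound 3. Compound 4 `Cc1cc(C)c(NC(=O)c2sccc2S(=O)(=O)Nc2onc(C)c2Cl)c(C)c1O` differs from compound 2 by one change, methoxy to hydroxy hydrogen in place of methyl on an oxygen on an aromatic ring in this series. For the measured compounds named here, no measured step makes this exact change. The closest steps replace a group on an aromatic carbon: a 1.1-fold higher number from compound 1 to compound 2 (0.06 log units; within the scatter) and a 4.4-fold higher number from compound 2 to compound 3 (0.64 log units; beyond the scatter) here. They range from nothing to modest and give no direction, so no step beyond the scatter is expected in this assay here. The expected step is a 1.3-fold lower number from compound 2 to compound 4 (0.12 log units; within the scatter) by this estimate. For compound 4 the estimated value is 6500 nM, expected between 2500 nM and 17000 nM in most repeats.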

Compound 4, maximal plasma concentration: 106000 nM
Compound 4: middle estimate off by 16-fold (1.21 log units), on the low side; the whole stated range lies below it.
By their numbers in this assay, from the lowest: compounds 1 and 2 (each within the scatter of the next); then compound 3; then compound 4.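

In this assay, for the compounds shown here, this position proved far more sensitive than the earlier compounds suggested: swapping the methyl on the oxygen for a hydrogen gives a 12-fold higher number from compound 2 to compound 4 (1.10 log units; beyond the scatter). The hydroxy group also exceeds the other two groups tested at this place, with a 2.8-fold higher number from compound 3 to compound 4 (0.45 log units; beyond the scatter) and a 14-fold higher number from compound 1 to compound 4 (1.15 log units; beyond the scatter). Nothing available here says what lies behind this rise. Going by these compounds, whether an amine or a carboxylic acid at this place would match the hydroxy group remains open. So does the effect of a longer chain, such as ethoxy, on the oxygen.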